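The source may hold more compounds than are shown below. What is called first, only, known or untested is meant among the compounds shown, and "the series" means these compounds.

The measured compounds: compound 1 `COC(=O)c1ccc(-c2cn(CCCC(=O)Nc3ccc(C)cc3)nn2)cc1` gives 2700 nM; compound 2 `Cc1ccc(NC(=O)CCCn2cc(-c3ccc(C(F)(F)F)cc3)nn2)cc1` gives 2300 nM. For compound 3 `COC(=O)c1ccc(-c2cn(CCCC(=S)Nc3ccc(-c4ccccc4)cc3)nn2)cc1` this work reports only a limit, > 100000 nM.

All three were tested in a functional assay on MDA-MB-231 cells (Homo sapiens) for inhibition, read by MTT assay, with a stated time of 72 h; a higher number here means a weaker inhibitor, a lower number a stronger inhibitor. The step of a 1.2-fold lower number from compound 1 to compound 2 (0.07 log units; within the scatter) rests on (trifluoromethyl in place of methoxycarbonyl on an aromatic carbon). Compound 3 sits at the limit of > 100000 nM in this assay, at which 1 of the 3 values shown sits, so its value is a limit and not a number. How the core of compound 3 differs from the core of compound 1 is not broken down here.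

Compound 4 `FC(F)(F)c1ccc(-c2cn(CCCC(=S)Nc3ccc(-c4ccccc4)cc3)nn2)cc1` has not been measured. It differs from compound 3 by trifluoromethyl in place of methoxycarbonyl on an aromatic carbon, the same change as from compound 1 to compound 2, made at the same place. Because that earlier step a 1.2-fold lower number from compound 1 to compound 2 (0.07 log units; within the scatter) stayed within the scatter, compound 4 is expected to remain near the limit reached by compound 3, an expected step that the limit leaves unreadable from compound 3 to compound 4. The estimate for compound 4 is 120000 nM, expected to lie between 50000 nM and 400000 nM.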

Compound 4, half-maximal inhibitory concentration: > 100000 nM
Compound 4 was reported as a limit (the forecaster's own chance of this, stated with the estimate: 75%); the middle value lies beyond the limit too.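

No step can be read from compound 3 to compound 4, because both are reported only as limits: the limit of > 100000 nM in this assay, at which 2 of the 4 values shown sit.

The compounds shown leave open whether 4-(trifluoromethyl)phenyl in place of 4-(methoxycarbonyl)phenyl changes the reading at all on the core of compound 3.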